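Compound 3 to compound 4: change on the sulfonyl sulfur

The source may hold more compounds than are shown below. What is called first, only, known or untested is meant among the compounds shown, and "the series" means these compounds.

Values in an ADME assay on HCT-116 cells (Homo sapiens) for cytotoxicity, read by CellTiter-Glo, with a stated time of 72 h; a lower number here means a stronger inhibitor, a higher number a weaker inhibitor (each one a limit, not a number):
- compound 1 `CC1CCN(C2CCN(S(=O)(=O)c3cccc(N)c3)CC2)CC1` gives > 5000 nM as a limit
- compound 2 `COc1cccc(S(=O)(=O)N2CCC(N3CCC(C)CC3)CC2)c1` gives > 5000 nM as a limit
- compound 3 `Cc1nc(Cl)sc1S(=O)(=O)N1CCC(N2CCC(C)CC2)CC1` gives > 10000 nM as a limit

In this assay compound 3 has only the limit > 10000 nM to show, so its place is the limit of > 10000 nM in this assay, at which 1 of the 3 values shown sits, and not a readable number. The two others stand at the limit of > 5000 nM in this assay, at which 2 of the 3 values shown sit, in the same way.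

Compound 4 `CC1CCN(C2CCN(S(=O)(=O)c3cn(C)cn3)CC2)CC1` carries 1-methyl-1H-imidazol-4-yl in place of 2-chloro-4-methyl-1,3-thiazol-5-yl on a sulfonyl sulfur.

Two measured steps change the group at that same sulfur: a step that the two limits leave unreadable from compound 1 to compound 3 and a step that the two limits leave unreadable from compound 2 to compound 3 are the ones that bear on it, and neither has a size that can be read. They give no ground for expecting a change in either direction. The estimated step is a number no higher from compound 3 to compound 4 (the limit leaves the size open) and is expected to stay within the scatter. Compound 4 is expected to be reported as a limit again. For compound 4 the estimate is 10000 nM, with an expected range from 5000 nM to 30000 nM.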

Compound 4, half-maximal inhibitory concentration: > 10000 nM
Compound 4: no number, only a limit (the forecaster's own chance of this, stated with the estimate: 85%); the middle value lies on the limit itself.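

In this assay compound 4 gives > 10000 nM, which is a limit and not a number. For the compounds shown here, no step between compound 4 and compound 1, compound 2 or compound 3 can be read. The compounds shown leave open whether any group on the sulfonyl sulfur shifts the value in this assay.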